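The compounds below may be only part of what the source reports. "The series", "measured", "known", "first", "only" and "open" are said of these compounds alone.

Measured compounds:
Compound 1, `COc1ccc(OC)c(-c2nc(C(c3ccccc3)c3ccccc3)sc2CC(=O)O)c1`, in an in vitro assay on HEK385-7 cells for displacement of a labelled ligand from prostaglandin D2 receptor 2 (Homo sapiens); on this read-out higher numbers stand for weaker inhibition and lower numbers for stronger inhibition: > 105 nM
Compound 2, `O=C(O)Cc1sc(C(c2ccc(F)cc2)c2ccc(F)cc2)nc1-c1cccc(F)c1`, in this assay: 1.4 nM

Compound 1 gives > 105 nM in this assay, which is a limit of the assay and not a number; this is the case described by the limit of > 105 nM in this assay, at which 1 of the 2 values shown sits. For the measured compounds named here, compound 2 gives 1.4 nM in this assay, the only number among the two values shown. Going by the values given here, no step between two measured compounds that differ in one place is available, so nothing about how a single change on the shared core shifts the read-out can be drawn from the data.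

Compound 3 `O=C(O)Cc1sc(C(c2ccc(F)cc2)c2ccc(F)cc2)nc1-c1ccncc1` has not yet been measured. It differs from compound 2 in one place: pyridin-4-yl in place of 3-fluorophenyl on an aromatic carbon. In the absence of any measured step, the expectation for the change from compound 2 to compound 3 rests only on the structural change itself, and the step of a 5.7-fold higher number from compound 2 to compound 3 (0.76 log units; beyond the scatter) is expected to be a modest loss of binding, a little beyond the usual scatter. Compound 3 is therefore estimated at 8 nM in this assay, with a range from 2 nM to 40 nM.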

Compound 3, half-maximal inhibitory concentration: 5.3 nM
Compound 3: middle estimate off by 1.5-fold (0.18 log units), on the high side; measured number inside the range.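

In this assay, for the compounds shown here, the exchange of 3-fluorophenyl for pyridin-4-yl on the aromatic carbon next to the ring nitrogen brings a 3.8-fold higher number from compound 2 to compound 3 (0.58 log units; beyond the scatter) and so gives the first measured reading of a single change on the shared core, a modest loss of binding that lies beyond the scatter. The position accepts a six-membered aromatic ring with a hetero atom and a hydrogen-bond acceptor in place of a ring of carbon only, and compound 3 still reads 5.3 nM in this comparison. Nothing measured here gives a reason for this step.

The step removes the fluorine and brings in the ring nitrogen at once, and the two cannot be separated here: an unsubstituted phenyl or a pyridin-3-yl group on this carbon would tell them apart. As far as these compounds go, how an amine on this carbon would read in this assay on the shared core also stays open.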